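Carbamate side chain variation: aryl versus arylalkyl at the ester oxygen

The source may hold more compounds than are shown below. What is called first, only, known or untested is meant among the compounds shown, and "the series" means these compounds.

Measured compounds in an assay on CHO cells for displacement of a labelled ligand from muscarinic acetylcholine receptor M5 (Homo sapiens), read by scintillation counting, with a stated time of 2 h; on this read-out higher numbers stand for weaker inhibition and lower numbers for stronger inhibition:
compound 1 `COc1ccc(CCOC(=O)N(c2ccccc2)C2CN3CCC2CC3)cc1`, 230 nM
compound 2 `Cc1ccc(COC(=O)N(c2ccccc2)C2CN3CCC2CC3)cc1F`, 30 nM
compound 3 `COc1ccc(COC(=O)N(c2ccccc2)C2CN3CCC2CC3)cc1F`, 40 nM

Compound 3 sits second highest of the three numbers. Its nearest neighbour is compound 2, a 1.3-fold higher number from compound 2 to compound 3 (0.12 log units; within the scatter), a gap within the scatter, so no order between compounds 2 and 3 is claimed. The gap to compound 1 is larger: a 5.8-fold lower number from compound 1 to compound 3 (0.76 log units; beyond the scatter), beyond the scatter.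

Compound 4 `O=C(OCCCc1ccccc1)N(c1ccccc1)C1CN2CCC1CC2` is the next member. It differs from compound 3 as follows: phenethyl in place of 3-fluoro-4-methoxyphenyl on a saturated chain carbon bound to an oxygen next to a carbonyl group. The measured steps that bear on this are the two that replaced the 4-methoxybenzyl of compound 1 at the same place with a substituted phenyl: a 7.7-fold lower number from compound 1 to compound 2 (0.88 log units; beyond the scatter) and a 5.8-fold lower number from compound 1 to compound 3 (0.76 log units; beyond the scatter). Both were modest and both ran toward lower numbers. Compound 4 moves the other way, back from an aryl group to an arylalkyl group, and one without the methoxy and fluorine. On this basis a step toward higher numbers is expected in this assay, of roughly the size seen on the way from compound 1 to compound 3, with a wider margin since the entering phenethyl matches neither measured side chain exactly. The expected step is a 7.5-fold higher number from compound 3 to compound 4 (0.88 log units; beyond the scatter), and compound 4 is estimated at 300 nM, within 100 nM to 1000 nM.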

Compound 4, inhibition constant: 260 nM
For compound 4 the middle estimate is 1.2-fold (0.06 log units) above the measured one, within the range that was stated.
By their numbers in this assay, from the lowest: compounds 2 and 3 (each within the scatter of the next); then compounds 1 and 4 (each within the scatter of the next).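

Phenethyl in place of 3-fluoro-4-methoxyphenyl gives a 6.5-fold higher number from compound 3 to compound 4 (0.81 log units; beyond the scatter) in this assay, and phenethyl in place of 3-fluoro-4-methylphenyl gives an 8.7-fold higher number from compound 2 to compound 4 (0.94 log units; beyond the scatter) in the same assay; both steps lie beyond the scatter and run toward weaker inhibition. Benzyl in place of 4-methoxyphenyl gives a 1.1-fold higher number from compound 1 to compound 4 (0.05 log units; within the scatter) and stays within the scatter, so at this place the 4-methoxy group of compound 1 is not needed for a number of that size, and the two side chains of compound 1 and compound 4 cannot be told apart here. Across these four compounds, the two with a directly attached substituted phenyl on the saturated chain carbon give the lower numbers and the two with an arylalkyl group give the higher ones, with no compound shown going against this split.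

No measurement shown gives a reason for this split. The compounds shown leave open how an unsubstituted phenyl, a chain longer than phenethyl or an amine at this place would read in this assay and whether the fluorine on the phenyl groups of compound 2 and compound 3 contributes to their lower numbers.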